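One Aryl Swap Against a Cytotoxicity Limit

The source may report more compounds than this note shows. Statements on the series, on what has been measured and on what is new or still open speak of the compounds shown alone.

Compound 1 `CCN(CC)c1cc2[nH]c(C3CCCCC3)nc2cc1NC(=O)OCC(F)(F)F`: > 100 ug/mL
Compound 2 `CCc1ccc(C(=O)Nc2cc3nc(C4CCCCC4)[nH]c3cc2N(CC)CC)cc1`: > 100 ug/mL

Both compounds were tested in an ADME assay on Vero cells (Chlorocebus sabaeus) for cytotoxicity, read by resazurin assay, with a stated time of 3 days; on this read-out higher numbers stand for weaker inhibition and lower numbers for stronger inhibition. For compound 2 the value > 100 ug/mL is a limit of the assay, not a number. For compound 1 the value > 100 ug/mL is likewise a limit. The two differ in one place, and the step that the two limits leave unreadable from compound 1 to compound 2 cannot be sized because of the limit of > 100 ug/mL in this assay, at which 2 of the 2 values shown sit.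

Compound 3 `CCN(CC)c1cc2[nH]c(C3CCCCC3)nc2cc1NC(=O)c1ccc(F)cc1F` has not yet been measured. It differs from compound 2 by 2,4-difluorophenyl in place of 4-ethylphenyl on a carbonyl carbon. Among the measured compounds shown here, only one measured step exists, a step that the two limits leave unreadable from compound 1 to compound 2, and it gives no readable size, so nothing measured bears directly on this change. With both measured values sitting at the limit, the step from compound 2 to compound 3 is expected to be a number no higher from compound 2 to compound 3 (the limit leaves the size open), nothing beyond the scatter. Compound 3 is therefore estimated at 100 ug/mL, with a range from 50 ug/mL to 200 ug/mL, most likely reported again as a limit.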

Compound 3, half-maximal inhibitory concentration: > 100 ug/mL
Compound 3 ended at the assay's limit; the forecaster's own chance of this, stated with the estimate: 75%; the middle value lies on the limit itself.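

No step can be read among compound 1, compound 2 and compound 3 in this assay, because every value rests on the same limit: the limit of > 100 ug/mL in this assay, at which 3 of the 3 values shown sit. The compounds shown leave open whether 4-ethylphenyl, 2,4-difluorophenyl or 2,2,2-trifluoroethoxy on the carbonyl carbon changes cytotoxicity at all.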